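The source may hold more compounds than are shown below. What is called first, only, known or untested is meant among the compounds shown, and "the series" means these compounds.

Three compounds have been measured in an assay on HEK293 cells for displacement of a labelled ligand from 5-hydroxytryptamine receptor 6 (Homo sapiens); on this read-out lower numbers stand for stronger inhibition and higher numbers for weaker inhibition:

Compound 1, `COc1cc(N2CCNCC2)c2c(c1)N(S(=O)(=O)c1ccccc1F)CCO2`, gives 0.159 nM.
Compound 2, `COc1cc(N2CCNCC2)c2c(c1)N(S(=O)(=O)c1ccccc1)CCO2`, gives 0.398 nM.
Compound 3, `CC1(C)CN(S(=O)(=O)c2ccccc2)c2cc(F)cc(C3CCNCC3)c2O1`, gives 3.98 nM.

Compound 2 and compound 1 share one core and differ only in fluoro in place of hydrogen on an aromatic carbon. That change lowered the number by a 2.5-fold lower number from compound 2 to compound 1 (0.40 log units; beyond the scatter), a step beyond the usual scatter, so the fluoro compound inhibits more strongly here.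

Compound 3 is built on a different core; the difference between the two cores is not broken down here. Its number in this assay is the highest of the three, standing a good way above both compound 2 and compound 1.

Compound 4, `CC1(C)CN(S(=O)(=O)c2cccc(F)c2)c2cc(F)cc(C3CCNCC3)c2O1`, is not yet measured. It is made from compound 3 by fluoro in place of hydrogen on an aromatic carbon. Going by the values given here, this is the same kind of change as the one from compound 2 to compound 1, but not the same: in compound 1 the fluoro sits ortho to a large group, whereas in compound 4 it sits meta to a large group, and the surrounding core differs as well. Among the compounds with values here, the only measured guide is the step from compound 2 to compound 1, which was modest; given the different position and core, a smaller gain is expected, with a fair chance of little change at all. For compound 4 in this assay the expected step is a 1.6-fold lower number from compound 3 to compound 4 (0.20 log units; within the scatter), and the expected value is 2.5 nM, likely between 0.8 nM and 8 nM.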

Compound 4, inhibition constant: 5.01 nM
For compound 4 the middle estimate is 2.0-fold (0.30 log units) below the measured one, within the range that was stated.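

In this assay, going from phenyl to 3-fluorophenyl on the sulfonyl group gave a 1.3-fold higher number from compound 3 to compound 4 (0.10 log units; within the scatter), so on this core the added fluoro made no clear difference to the read-out. The gain seen when fluoro was added on the other core therefore did not carry over, and the two steps really do differ: the same change on two cores in this assay, a 2.5-fold lower number (0.40 log units; beyond the scatter) from compound 2 to compound 1 and a 1.3-fold higher number (0.10 log units; within the scatter) from compound 3 to compound 4, 3.2-fold (0.50 log units) apart, beyond the scatter of two such steps. Going by these compounds alone, this does not show that the core alone decides the outcome, as the fluoro in compound 4 sits meta to a large group while the one in compound 1 stands at a different place on its ring, and with only one pair of compounds on each core, the effect of the core cannot be separated from the effect of the position.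

The compounds shown leave open whether fluoro at one and the same ring position would give matching steps on both cores, which is the comparison that would separate these two explanations. They also leave open how a different group on that phenyl ring, such as a chlorine atom or a nitrile, would compare with fluoro on either core.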